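The source may report more compounds than this note shows. Statements on the series, on what has been measured and on what is new or still open speak of the compounds shown alone.

Compound 2, `CCCS(=O)(=O)N1CCC(CNC(=O)c2ccccc2OC(F)(F)F)(C(=O)N2CCOCC2)CC1`, was tested in an assay on isolated protein for inhibition of sodium- and chloride-dependent glycine transporter 1 (Homo sapiens) (a lower number here means a stronger inhibitor, a higher number a weaker inhibitor), and gave 88.4 nM. Among the two numbers measured, compound 2 stands highest; its nearest neighbour is compound 1, `CCCS(=O)(=O)N1CCC(CNC(=O)c2ccc(F)cc2C(F)(F)F)(C(=O)N2CCOCC2)CC1`, which in this assay gave 67.8 nM. Going by the values given here, the only measured step, a 1.3-fold higher number from compound 1 to compound 2 (0.12 log units; within the scatter), exchanged one aromatic group on the carbonyl carbon for another and stayed within the scatter.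

Compound 3, `CCCS(=O)(=O)N1CCC(CNC(=O)c2ccccc2Cl)(C(=O)N2CCOCC2)CC1`, is the next compound. It differs from compound 2 in one place: chloro in place of trifluoromethoxy on an aromatic carbon. Seen one bond further out, this is 2-(trifluoromethoxy)phenyl to 2-chlorophenyl. The measured step bears on it only loosely, since it also changed the aromatic group and moved the number very little. Among the compounds with values here, with no closer precedent, compound 3 is expected to sit near compound 2, a step of a 1.1-fold higher number from compound 2 to compound 3 (0.05 log units; within the scatter) that need not exceed the scatter. The estimate for compound 3 is 100 nM, with a range from 40 nM to 250 nM.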

Compound 3, half-maximal inhibitory concentration in the sodium- and chloride-dependent glycine transporter 1 assay: 9.7 nM
Beside the measured number, compound 3's estimate is 10-fold (1.01 log units) above it; measured number outside the range, below it.
By their numbers in the sodium- and chloride-dependent glycine transporter 1 assay, from the lowest: compound 3; then compounds 1 and 2 (each within the scatter of the next).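

Going by these compounds alone, in the sodium- and chloride-dependent glycine transporter 1 assay, the earlier compounds suggested that exchanging this aromatic group changes little, yet the single swap of trifluoromethoxy for chloro, on an aromatic carbon ortho to a large group, gives a 9.1-fold lower number from compound 2 to compound 3 (0.96 log units; beyond the scatter), and the wider change of aromatic group gives a 7.0-fold lower number from compound 1 to compound 3 (0.84 log units; beyond the scatter). In a physicochemical assay for lipophilicity (on this read-out lower numbers stand for lower lipophilicity and higher numbers for higher lipophilicity), compound 2 gives < 1.4, which is a limit of the assay and not a number. In the physicochemical assay compound 3 gives < 1.4, which is also a limit.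

From the compounds shown here alone, the step between these two compounds in that read-out cannot be read, because both sit at the same limit: the limit of < 1.4 in the physicochemical assay, at which 2 of the 2 values shown sit. Also open is how a bromo, methyl or nitrile group in the same place would compare with chloro.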